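Sulfonamide substituent variation on the acetylene-linked aryloxyacetic acid series

This account rests on a few compounds, and the source may have more. Where it says the series, first, only, none or still open, it means among the compounds named here.

Measured so far:
compound 1 `Cc1ncc(S(=O)(=O)N(C)C)cc1C#Cc1cc(Cl)ccc1OCC(=O)O` — 41 nM
compound 2 `Cc1ccc(S(=O)(=O)N(C)CCCN(C)C)cc1C#Cc1cc(Cl)ccc1OCC(=O)O` — 287 nM

In an assay on CHO cells for displacement of a labelled ligand from prostaglandin D2 receptor 2 (Homo sapiens), read by scintillation counting (a lower number here means a stronger inhibitor, a higher number a weaker inhibitor), compound 1 gives 41 nM, whereas compound 2 gives 287 nM, the higher of the two numbers shown, and its gap to compound 1 lies beyond the scatter of this assay. Within the data shown here, the two compounds differ in more than one place, so no single step between them is counted.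

Compound 3 `Cc1ccc(S(=O)(=O)NC(C)(C)C)cc1C#Cc1cc(Cl)ccc1OCC(=O)O` is not yet measured in this assay. It departs from compound 2 only at the sulfonyl sulfur: (tert-butyl)amino in place of (3-(dimethylamino)propyl)(methyl)amino on a sulfonyl sulfur. The group that leaves carries an acceptor and no donor; the group that enters carries a donor and no acceptor, and is smaller by the count shown.

Of the two measured compounds, the one with the shorter sulfonamide substituent, compound 1, shows the lower number, so compound 3, with its shorter substituent, is expected to move in the same direction, though the change in the core between compound 1 and compound 2 limits how far that comparison carries. The estimate for compound 3 is 90 nM, with a range of 30 nM to 270 nM. The step from compound 2 that this expects is a 3.2-fold lower number from compound 2 to compound 3 (0.50 log units; beyond the scatter), a moderate lowering of the number, beyond the usual scatter but not certain to be so.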

Compound 3, inhibition constant: 5 nM
Estimate against measurement, compound 3: 18-fold (1.26 log units) above; measured number outside the range, below it.
By their numbers in this assay, from the lowest: compound 3; then compound 1; then compound 2.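

In this assay the sulfonyl sulfur proves highly sensitive to its substituent: (tert-butyl)amino in place of (3-(dimethylamino)propyl)(methyl)amino gives a 57-fold lower number from compound 2 to compound 3 (1.76 log units; beyond the scatter) with the rest of the structure unchanged. Among these compounds, this is the first change that can be read at one place, but the entering group is smaller, carries a hydrogen-bond donor and lacks the acceptor of the group that leaves, so the step does not separate these differences. Nothing at hand accounts for the size of this step.

Open, going by these compounds, is whether the gain survives loss of the sulfonamide hydrogen, which (tert-butyl)(methyl)amino on the same sulfur would test, and whether a (3-methoxypropyl)amino chain behaves like either measured group. Also open, on these data alone, is how (tert-butyl)amino behaves on the core of compound 1.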